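The source may report more compounds than this note shows. Statements on the series, on what has been measured and on what is new or still open speak of the compounds shown alone.

Measured in a functional assay on KB cells (Homo sapiens) for antiproliferative activity, read by sulforhodamine B assay, with a stated time of 3 days; a lower number here means that less compound is needed, a higher number that more compound is needed for the effect:
Compound 1 `CCOc1ccc(-c2cc(=O)c3c(o2)C(CC)(CC)C(=O)C(CC)=C3O)cc1`: > 52.4 uM, a limit
Compound 2 `CCC1=C(O)c2c(oc(-c3cccc(F)c3)cc2=O)C(CC)(CC)C1=O`: > 56.2 uM, a limit
Compound 3 `CCC1=C(O)c2c(oc(-c3ccc(OC)cc3C)cc2=O)C(CC)(CC)C1=O`: 20.9 uM

Among the measured compounds shown here, compound 3 holds the only actual number in this small set, as the other two values are limits. Compound 4 `CCC1=C(O)c2c(oc(-c3ccc(OC)c(F)c3)cc2=O)C(CC)(CC)C1=O` has not yet been measured. It keeps the core of compound 3, but 3-fluoro-4-methoxyphenyl takes the place of 4-methoxy-2-methylphenyl: 3-fluoro-4-methoxyphenyl in place of 4-methoxy-2-methylphenyl on an aromatic carbon.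

For the measured compounds named here, two measured steps bear on this change: an at least 2.5-fold lower number from compound 1 to compound 3 (0.39 log units; beyond the scatter), and an at least 2.6-fold lower number from compound 2 to compound 3 (0.42 log units; beyond the scatter). In both, 4-methoxy-2-methylphenyl is the group that enters, whereas here it leaves. The entering group shares its fluorine with the 3-fluorophenyl of compound 2. A modest step to a higher number in this assay is therefore expected, and a limit is a real possibility. The expected step is a 2.2-fold higher number from compound 3 to compound 4 (0.33 log units; beyond the scatter). For compound 4 the estimated value is 45 uM, with an expected range from 18 uM to 100 uM.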

Compound 4, concentration for half-maximal effect: 26.7 uM
The estimate for compound 4 lay 1.7-fold (0.23 log units) above the measured number; the measured number falls inside the stated range.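

In this assay, exchanging 4-methoxy-2-methylphenyl for 3-fluoro-4-methoxyphenyl gives a 1.3-fold higher number from compound 3 to compound 4 (0.11 log units; within the scatter), so a methyl-bearing ring is not needed for a measured number at this position among the compounds shown. Placing methoxy on the 3-fluorophenyl ring gives an at least 2.1-fold lower number from compound 2 to compound 4 (0.32 log units; beyond the scatter), the first single-group change shown in which methoxy alone replaces hydrogen and a limit gives way to a number. Replacing 4-ethoxyphenyl with 3-fluoro-4-methoxyphenyl gives an at least 1.9-fold lower number from compound 1 to compound 4 (0.29 log units; that floor lies within the scatter), so that change alone does not yet separate the two groups beyond the scatter.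

The compounds shown leave open how an amine, a carboxylic acid or a longer alkoxy chain on this aromatic ring would read. The full size of the step away from compound 2 also stays open, since its value is only a limit: the limit of > 56.2 uM in this assay, at which 1 of the 4 values shown sits.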